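This account rests on a few compounds, and the source may have more. Where it says the series, first, only, none or still open, it means among the compounds named here.

Compound 1 `COc1ccccc1-c1ccc(-c2nnc(N(C)Cc3ccc4nccn4c3)o2)cc1` and compound 2 `Cc1ccccc1-c1ccc(-c2nnc(N(C)Cc3ccc4nccn4c3)o2)cc1` share one core; compound 3 `COc1cc(-c2c(C)nn(C)c2C)ccc1-c1nnc(N(C)Cc2ccc3nccn3c2)o1` rests on a different core, and the difference between the two cores is not broken down here. In an assay on isolated protein for inhibition of tyrosine-protein kinase Mer (Homo sapiens), read by LC-MS (on this read-out lower numbers stand for stronger inhibition and higher numbers for weaker inhibition), compound 1 gives 31.6 nM, compound 2 gives 12.6 nM and compound 3 gives 15.9 nM. The change methyl in place of methoxy on an aromatic carbon brought a 2.5-fold lower number from compound 1 to compound 2 (0.40 log units; beyond the scatter). Compound 4 `Cc1cc(-c2c(C)nn(C)c2C)ccc1-c1nnc(N(C)Cc2ccc3nccn3c2)o1` carries the same kind of change on the core of compound 3, (methyl in place of methoxy on an aromatic carbon); the place here is meta to a 1,3,5-trimethyl-1H-pyrazol-4-yl group, which the place in compound 1 does not have. Because a 2.5-fold lower number from compound 1 to compound 2 (0.40 log units; beyond the scatter) was seen, a like step is expected for compound 4, namely a 2.3-fold lower number from compound 3 to compound 4 (0.36 log units; beyond the scatter). Compound 4 is therefore estimated at 7 nM in this assay, with a range from 3.5 nM to 14 nM.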

Compound 4, half-maximal inhibitory concentration: 3.16 nM
The estimate for compound 4 lay 2.2-fold (0.35 log units) above the measured number; measured number below the stated range.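

In this assay, methyl in place of methoxy on an aromatic carbon gave a 5.0-fold lower number from compound 3 to compound 4 (0.70 log units; beyond the scatter) and matches the earlier step in direction and, within the scatter, in size: the same change on two cores in this assay, a 2.5-fold lower number (0.40 log units; beyond the scatter) from compound 1 to compound 2 and a 5.0-fold lower number (0.70 log units; beyond the scatter) from compound 3 to compound 4, 2.0-fold (0.30 log units) apart, within the scatter of two such steps.

The change therefore carried over between these two cores, with or without the 1,3,5-trimethyl-1H-pyrazol-4-yl group. Two pairs in one assay do not show that it would carry to further cores, and they do not explain why the number falls.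

The compounds shown leave open how a chlorine, an ethyl group or a hydroxyl group would compare with methyl at this place. They also leave open whether the step holds on a core outside these two.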